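Turning One Ring Centre: Clearance of a Mirror-Image Isomer

The compounds below may be only part of what the source reports. "The series", "measured", "known", "first", "only" and "open" are said of these compounds alone.

Measured compounds:
Compound 1 `COC(c1cc(Cl)c2c(c1Cl)C(=O)N(Cc1c(C)cc(C)[nH]c1=O)CC2)C1CCOC1`: 136 uL/min; 93.3 uL/min; 128 uL/min; 108 uL/min (4 entries)
Compound 2 `CCOC(c1cc(Cl)c2c(c1Cl)C(=O)N(Cc1c(C)cc(C)[nH]c1=O)CC2)C1CS(=O)(=O)C1`: 45.7 uL/min; 124 uL/min (2 entries)
Compound 3 `Cc1cc(C)c(CN2CCc3c(Cl)cc([C@@H](CO)[C@@H]4CCCO4)c(Cl)c3C2=O)c(=O)[nH]1`: 70.3 uL/min

All three share a core and were run in an ADME assay on microsomes from liver (Homo sapiens) for metabolic stability, read by LC-MS, using NADPH, with stated times of 10 min and 45 min, tested at 1 uM; on this read-out higher numbers stand for fast clearance and lower numbers for slow clearance. Compound 1 has repeated entries (the several entries of compound 1 in this assay, 136 uL/min; 93.3 uL/min; 128 uL/min; 108 uL/min (4 entries)), and its entries scatter but sit toward the faster-clearance end. Compound 2 was measured twice (the several entries of compound 2 in this assay, 45.7 uL/min; 124 uL/min (2 entries)), and its two entries lie far apart, a reminder of how wide repeated runs of this kind can spread. Going by the values given here, compound 3 has one value in this assay, and two further measurements gave no single number, so its single value is the only anchor for the step that follows.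

Compound 4 `Cc1cc(C)c(CN2CCc3c(Cl)cc([C@@H](CO)[C@H]4CCCO4)c(Cl)c3C2=O)c(=O)[nH]1` is the not yet measured partner of compound 3. The change is the two compounds have the same atoms and bonds and differ only in configuration as drawn: 1 of 2 stereo elements differ; a stereocentre at a saturated ring carbon is drawn S in compound 3 and R in compound 4. The two compounds have the same atoms and bonds and differ only in configuration as drawn.

Among the compounds with values here, no measured pair in this set shows what such a change does to clearance. With nothing else altered, the step of a 1.0-fold lower number from compound 3 to compound 4 (0.00 log units; within the scatter) is expected to stay within the usual scatter, in no particular direction. Compound 4 is therefore estimated to give 70 uL/min, with a range from 35 uL/min to 140 uL/min.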

Compound 4, intrinsic clearance in a liver preparation (reported as CLH), per the amount of preparation that the assay uses: 43 uL/min
For compound 4 the middle estimate is 1.6-fold (0.21 log units) above the measured one, within the range that was stated.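

In this assay, going by these compounds alone, turning one saturated ring carbon from S to R gives the first single-change step in this set (a 1.6-fold lower number from compound 3 to compound 4 (0.21 log units; within the scatter)), so at this position the drawn configuration does not clearly separate the two compounds. Repeated runs show how little weight a gap of this size can bear, since the two entries of compound 2 lie further apart than compound 3 and compound 4 do: the several entries of compound 2 in this assay, 45.7 uL/min; 124 uL/min (2 entries). The pair is still a clean comparison, because no other feature changes and any real gap could come only from this one centre: the fact that compounds 3 and 4 differ only in the configuration as drawn.

On these data alone, compound 3 and compound 4 each rest on one number here, so a small real preference for one configuration can be neither confirmed nor ruled out, and the second stereo element, which is the same in both, remains untested by this step. Also open, as far as these compounds go, is whether the same turn would stay this quiet with a different group in place of the hydroxyl, such as an amine or a carboxylic acid.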